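The source may report more compounds than this note shows. Statements on the series, on what has been measured and on what is new or still open speak of the compounds shown alone.

Of the compounds shown here, two built on one shared core have been tested in a functional assay on PC-3 cells (Homo sapiens) for inhibition, read by MTT assay, with a stated time of 72 h; on this read-out lower numbers stand for stronger inhibition and higher numbers for weaker inhibition. Compound 1 `CC(C)n1ncc2c(C(=O)NCc3cn(-c4ccccc4)nn3)cccc21` gives 26000 nM. Compound 2 `Cc1ccc(-n2cc(CNC(=O)c3cccc4c3cnn4C(C)C)nn2)cc1C` gives 23400 nM. Among the measured compounds shown here, the single change between them, a 1.1-fold lower number from compound 1 to compound 2 (0.05 log units; within the scatter), is too small to count as a real difference, so on the numbers so far compound 2 stands level with compound 1, and the two values cannot be told apart.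

Compound 3 `COc1ccc(Cn2cc(CNC(=O)c3cccc4c3cnn4C(C)C)nn2)cc1` differs from compound 2 in one place: 4-methoxybenzyl in place of 3,4-dimethylphenyl on an aromatic nitrogen. For the measured compounds named here, the only measured step that touches this part of the molecule is the one from compound 1 to compound 2, and it stayed within the scatter, which hints that swapping groups at this ring nitrogen does little to the read-out. The present change is larger in kind, since a benzyl group rather than an aryl group enters and brings one hydrogen-bond acceptor, so the outlook is less certain. Compound 3 is therefore expected to land near compound 2, with a step of a 1.1-fold higher number from compound 2 to compound 3 (0.03 log units; within the scatter) that is not expected to pass the scatter. For compound 3 the estimate is 25000 nM, with a range from 10000 nM to 70000 nM.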

Compound 3, half-maximal inhibitory concentration: 34000 nM
Estimate against measurement, compound 3: 1.4-fold (0.13 log units) below; low and high end bracket the measured number.
By their numbers in this assay, from the lowest: compounds 2, 1 and 3 (each within the scatter of the next).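

In this assay the 4-methoxybenzyl group gives a 1.5-fold higher number from compound 2 to compound 3 (0.16 log units; within the scatter) when it replaces 3,4-dimethylphenyl and a 1.3-fold higher number from compound 1 to compound 3 (0.12 log units; within the scatter) when it replaces phenyl, and neither step passes the scatter. This goes further than the earlier comparison, which only exchanged one aryl group for another on the aromatic nitrogen: a benzyl group carrying one hydrogen-bond acceptor now stands there, and the three compounds still cannot be told apart. The data shown offer no measurement that could explain why the read-out stays so flat across these changes.

From the compounds shown here alone, all three groups at this position contain a six-membered aromatic ring of carbon only, so it remains open whether a group without such a ring, such as a short alkyl chain, an amine or a carboxylic acid, would produce a step beyond the scatter. Also unknown is whether a change elsewhere on the shared core would move the number more than these exchanges on the aromatic nitrogen have done.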